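Series notes: cyano for fluoro on the way to compound 4

A few compounds are considered here, and "the series" means these few. Any claim that something is new, unique, unknown or untested is made for them only; others in the source may bear on it.

Measured so far:
- compound 1 `Cc1ccccc1-c1noc(-c2ccc(C3CCCCC3)cc2)n1`: > 10000 nM
- compound 2 `Cc1cc(C(=O)O)ccc1-c1noc(-c2ccc(C3CCCCC3)cc2)n1`: > 10000 nM
- compound 3 `Cc1cc(CCC(=O)O)ccc1-c1noc(-c2ccc(OC(C)C)c(F)c2)n1`: > 10000 nM

Among the measured compounds shown here, every value so far is a limit of a functional assay on CHO cells with sphingosine 1-phosphate receptor 4 (Homo sapiens) as the target, read by GTPgammaS binding (a higher number here means that more compound is needed for the effect, a lower number that less compound is needed), rather than a number. Compound 1 reaches only a limit. Compound 2 likewise reaches only a limit. Compound 3 stands at the same limit, shared with the other two, so that all three sit at the limit of > 10000 nM in this assay, at which 3 of the 3 values shown sit, and nothing separates them. For the measured compounds named here, the single step with both ends measured, a step that the two limits leave unreadable from compound 1 to compound 2, is unreadable between its two limits.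

Compound 4 `Cc1cc(CCC(=O)O)ccc1-c1noc(-c2ccc(OC(C)C)c(C#N)c2)n1` differs from compound 3 by cyano in place of fluoro on an aromatic carbon. Going by the values given here, no measured step touches either a cyano or a fluoro group, so no step bears on this change. The step of a number no higher from compound 3 to compound 4 (the limit leaves the size open) is therefore expected to stay within the scatter, with no direction.

Compound 4 is expected to give about 10000 nM, in the range 2500 nM to 40000 nM, most likely again reported as a limit.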

Compound 4, half-maximal effective concentration: > 10000 nM
Compound 4: only a limit was reported (the forecaster's own chance of this, stated with the estimate: 75%); the middle value lies on the limit itself.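

Compound 3 and compound 4 are both reported only as limits in this assay, so no step can be read between them. The compounds shown leave open which structural change, if any, gives a number rather than a limit: the limit of > 10000 nM in this assay, at which 4 of the 4 values shown sit.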